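Chloro for Methyl on the Shared Core and Metabolic Stability

The source may report more compounds than this note shows. Statements on the series, on what has been measured and on what is new or still open speak of the compounds shown alone.

Three compounds share one core and were measured in an ADME assay (Homo sapiens) for metabolic stability; a lower number here means that less of the compound is left, a higher number that more of the compound is left. Compound 1 `Cc1nc(N[C@@H]2C[C@H]3CC[C@@H]2C3)c2cc(-c3ccc(Cl)c(Cl)c3)ccc2n1` gives 56%. Compound 3 `Clc1nc(N[C@@H]2C[C@H]3CC[C@@H]2C3)c2cc(-c3ccc(Cl)c(Cl)c3)ccc2n1` gives 69%. The change between them is chloro in place of methyl on an aromatic carbon, and it brings a number 13 percentage points higher from compound 1 to compound 3 (beyond the scatter). Compound 2 `Cc1nc(N[C@@H]2C[C@H]3CC[C@@H]2C3)c2cc(-c3cccc(C(F)(F)F)c3)ccc2n1` gives 75%; the difference between its core and that of compound 1 is not broken down here. Compound 2 stands beyond the scatter above compound 1, while its number and that of compound 3 lie within the scatter of each other.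

Compound 4 `FC(F)(F)c1cccc(-c2ccc3nc(Cl)nc(N[C@@H]4C[C@H]5CC[C@@H]4C5)c3c2)c1` has not been measured. It differs from compound 2 by chloro in place of methyl on an aromatic carbon, the same change as from compound 1 to compound 3, at a place described in the same words. The step expected is a number 8 percentage points higher from compound 2 to compound 4 (within the scatter), set beside the measured a number 13 percentage points higher from compound 1 to compound 3 (beyond the scatter). This rests on one pair only, so the range is kept wide. Compound 4 is therefore expected to give about 83% in this assay, likely between 70% and 94%.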

Compound 4, percent of the compound remaining: 58%
Estimate against measurement, compound 4: 25 percentage points above; measured number below the stated range.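

In this assay, putting chloro in place of methyl on the aromatic carbon between two ring nitrogen atoms brings a number 17 percentage points lower from compound 2 to compound 4 (beyond the scatter) on this second core. The same swap therefore does not carry over unchanged, and here it moves the number in the opposite direction from the earlier pair: the same change on two cores in this assay, a number 13 percentage points higher (beyond the scatter) from compound 1 to compound 3 and a number 17 percentage points lower (beyond the scatter) from compound 2 to compound 4, 30 percentage points apart, beyond the scatter of two such steps

What this shows is that a step measured on one core in this series cannot simply be added to a compound with a different core. It does not show why the two steps part, and two pairs cannot tell which of them a further core would follow, or whether it would follow either one.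

The compounds shown leave open how the swap behaves when the aromatic ring carrying chloro groups in compound 1 and trifluoromethyl in compound 2 bears a methoxy group or a nitrile instead. They also leave open what an amine or a longer chain in place of the methyl or chloro would do.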